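The source may hold more compounds than are shown below. What is called first, only, known or untested is meant among the compounds shown, and "the series" means these compounds.

Compound 1, `CCCCc1nc(C(C)C)c(CC(=O)OC)c(=O)n1Cc1ccc(-c2ccccc2-c2noc(=O)[nH]2)cc1`, gives 10.5% in an ADME assay on microsomes from liver (Homo sapiens) for metabolic stability, with a stated time of 30 min; on this read-out higher numbers stand for a more stable compound and lower numbers for a less stable compound.
Compound 2, `CCCCc1nc(C(C)C)c(CC(=O)OCCC)c(=O)n1Cc1ccc(-c2ccccc2-c2noc(=O)[nH]2)cc1`, gives 7.2% in this assay.
Compound 3, `CCCCOC(=O)Cc1c(C(C)C)nc(CCCC)n(Cc2ccc(-c3ccccc3-c3noc(=O)[nH]3)cc2)c1=O`, gives 7.1% in this assay.

On the numbers as written, compound 3 holds the lowest of the three, yet the steps leading to it, a number 3.4 percentage points lower from compound 1 to compound 3 (within the scatter) and a number 0.1 percentage points lower from compound 2 to compound 3 (within the scatter), both fall within the scatter, so the three cannot be placed in any order. Compound 4, `CCCCc1nc(C(C)C)c(CC(=O)OC2CCCCC2)c(=O)n1Cc1ccc(-c2ccccc2-c2noc(=O)[nH]2)cc1`, has not yet been measured. It differs from compound 3 by cyclohexyl in place of butyl on an oxygen next to a carbonyl group. All three measured steps alter the same chain on that oxygen, and besides the two already named, a number 3.3 percentage points lower from compound 1 to compound 2 (within the scatter) also stays within the scatter. Nothing measured here has moved this assay beyond its scatter by lengthening or reshaping that chain. The step to compound 4 is therefore expected to be a number 0.6 percentage points lower from compound 3 to compound 4 (within the scatter), that is, no change beyond the scatter. Compound 4 is accordingly estimated at 6.5%, within a range from 2% to 14%.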

Compound 4, percent of the compound remaining: 13.3%
Compound 4: middle estimate off by 6.8 percentage points, on the low side, within the range that was stated.
By their numbers in this assay, from the lowest: compounds 3, 2, 1 and 4 (each within the scatter of the next).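

Cyclohexyl brings a ring onto the oxygen next to a carbonyl group, yet every step to compound 4 in this assay stays within the scatter (a number 6.2 percentage points higher from compound 3 to compound 4 (within the scatter); a number 6.1 percentage points higher from compound 2 to compound 4 (within the scatter); a number 2.8 percentage points higher from compound 1 to compound 4 (within the scatter)). The lack of any step beyond the scatter, already seen among methyl, propyl and butyl, therefore holds for this ring as well, and the four compounds still cannot be placed in any order. No evidence is available to explain where these numbers fall.

Still open, from the compounds shown here alone, is whether a phenyl ring or a chain carrying an amine at this place would move this read-out beyond its scatter. Also open, going by these compounds, is how a hydrogen on that oxygen, which would give a carboxylic acid, would compare.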